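The source may hold more compounds than are shown below. What is called first, only, known or untested is meant among the compounds shown, and "the series" means these compounds.

Measured in a physicochemical assay for solubility, measured as kinetic solubility, at pH 7.4; a lower number here means a less soluble compound, a higher number a more soluble compound:
compound 1 `COc1cc(N2CCC(C(=O)N3CCOCC3)CC2)ccc1Nc1nc(NC2CCCCC2)c2nc[nH]c2n1`: 19000 nM
compound 2 `COc1cc(N2CCC(CC(=O)N3CCN(C)CC3)CC2)ccc1Nc1nc(NC2CCCCC2)c2nc[nH]c2n1`: 38000 nM
compound 3 `COc1cc(N2CCC(CC(=O)N3CCC(N(C)C)C3)CC2)ccc1Nc1nc(NC2CCCCC2)c2nc[nH]c2n1`: 75000 nM

Compound 3 stands clearly apart from only one of the other two compounds. The measured comparison gives a 3.9-fold higher number from compound 1 to compound 3 (0.60 log units; beyond the scatter). Against its nearest neighbour, the comparison gives a 2.0-fold higher number from compound 2 to compound 3 (0.30 log units; within the scatter).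

Compound 4 `COc1cc(N2CCC(CC(=O)N3CCCC3)CC2)ccc1Nc1nc(NC2CCCCC2)c2nc[nH]c2n1` carries hydrogen in place of dimethylamino on a saturated ring carbon, so that 3-(dimethylamino)pyrrolidin-1-yl becomes pyrrolidin-1-yl: hydrogen in place of dimethylamino on a saturated ring carbon.

Among the compounds with values here, no measured step makes this exact change, so the evidence is indirect. The closest guide is the comparison that gives a 3.9-fold higher number from compound 1 to compound 3 (0.60 log units; beyond the scatter), a modest step, since compound 1 also lacks dimethylamino, although it has a different amide and linkage. The other two steps, a 2.0-fold higher number from compound 1 to compound 2 (0.30 log units; within the scatter) and a 2.0-fold higher number from compound 2 to compound 3 (0.30 log units; within the scatter), stay within the scatter and add little on their own. Taken together, they still run in the same direction across the three compounds.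

A modest move to a lower number is therefore expected in this assay, roughly the reverse of the step to compound 3 from compound 1. The expected step is a 4.2-fold lower number from compound 3 to compound 4 (0.62 log units; beyond the scatter). For compound 4 the estimated value is 18000 nM, with an expected range from 6000 nM to 45000 nM.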

Compound 4, solubility: 19000 nM
Beside the measured number, compound 4's estimate is 1.1-fold (0.02 log units) below it; low and high end bracket the measured number.
By their numbers in this assay, from the lowest: compounds 1, 4, 2 and 3 (each within the scatter of the next, the first and the last beyond it).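

In this assay, within the data shown here, hydrogen in place of dimethylamino on this saturated ring carbon, two ring bonds from the ring nitrogen, gives a 3.9-fold lower number from compound 3 to compound 4 (0.60 log units; beyond the scatter); this is the first reading of this single change, and it lies beyond the scatter. The other two new pairs stay within the scatter: pyrrolidin-1-yl in place of 4-methylpiperazin-1-yl gives a 2.0-fold lower number from compound 2 to compound 4 (0.30 log units; within the scatter), and ((pyrrolidin-1-yl)carbonyl)methyl in place of (morpholin-4-yl)carbonyl gives no change at the digits printed from compound 1 to compound 4 (within the scatter), so neither amide change can be told apart from repeat variation in this read-out. No supporting measurement among the compounds shown accounts for the step at this position.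

Open, as far as these compounds go, is whether the step belongs to dimethylamino specifically or would also appear with another group on the same ring carbon, such as a primary amine, a hydroxyl or a carboxylic acid. Also open, from the compounds shown here alone, is how far the amine nitrogen can be moved, for example with a longer chain such as dimethylaminomethyl on that carbon, while keeping the step seen with compound 3.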